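This account rests on a few compounds, and the source may have more. Where it says the series, first, only, none or still open, it means among the compounds named here.

Of the compounds shown here, three sharing one core have been measured in a functional assay for antagonist activity at thyroid hormone receptor beta (Homo sapiens), read by fluorescence polarization, with a stated time of 3 h; on this read-out higher numbers stand for weaker inhibition and lower numbers for stronger inhibition. Compound 1 `CN(Cc1ccccc1)C(=O)c1sc(-c2ccc(S(C)(=O)=O)c([N+](=O)[O-])c2)nc1C(F)(F)F` gives 3300 nM, compound 2 `Cc1nc(-c2ccc(S(C)(=O)=O)c([N+](=O)[O-])c2)sc1C(=O)N1CCC(C)CC1` gives 7400 nM, and compound 3 `CC1CCN(C(=O)c2sc(-c3ccc(S(C)(=O)=O)c([N+](=O)[O-])c3)nc2C(F)(F)F)CC1` gives 310 nM, the lowest of the three numbers and beyond the scatter from both of the others. Two steps lead to compound 3: an 11-fold lower number from compound 1 to compound 3 (1.03 log units; beyond the scatter), with 4-methylpiperidin-1-yl in place of benzyl(methyl)amino on a carbonyl carbon, and a 24-fold lower number from compound 2 to compound 3 (1.38 log units; beyond the scatter), with trifluoromethyl in place of methyl on an aromatic carbon. Compound 4 `CS(=O)(=O)c1ccc(-c2nc(C(F)(F)F)c(C(=O)N3CCCCC3)s2)cc1[N+](=O)[O-]` differs from compound 3 by hydrogen in place of methyl on a saturated ring carbon, three ring bonds from the ring nitrogen. Going by the values given here, no measured step removes a substituent from that ring. Only the first of the two steps touches the amide part at all, and it exchanged the whole amine rather than a single methyl, so it gives little direct guidance. The expected step of a 1.6-fold higher number from compound 3 to compound 4 (0.21 log units; within the scatter) is therefore small, at most a modest weakening, and within the scatter. Compound 4 is estimated at 500 nM, with a range of 200 nM to 1300 nM.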

Compound 4, half-maximal inhibitory concentration: 660 nM
Estimate against measurement, compound 4: 1.3-fold (0.12 log units) below; the range from low to high includes it.
By their numbers in this assay, from the lowest: compound 3; then compound 4; then compound 1; then compound 2.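

In this assay the loss of the single methyl from the saturated ring carbon, three ring bonds from the ring nitrogen, gives a 2.1-fold higher number from compound 3 to compound 4 (0.33 log units; beyond the scatter) and so shows that this one carbon alone moves the number, modestly but beyond the scatter. The whole-amine exchange can now be read in two parts, since piperidin-1-yl alone gives a 5.0-fold lower number from compound 1 to compound 4 (0.70 log units; beyond the scatter) and the methyl adds to this to reach the larger 11-fold lower number from compound 1 to compound 3 (1.03 log units; beyond the scatter) in total. Nothing in the available data bears on why the methyl has this effect.

From the compounds shown here alone, at this ring carbon only methyl and hydrogen are compared, so what an ethyl, a hydroxyl group or a carboxylic acid would do there remains open. Also open, going by these compounds, is whether the methyl counts equally when methyl replaces trifluoromethyl on the aromatic carbon.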